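Shortening the amide chain in the stilbene-acrylamide series

This account rests on a few compounds, and the source may have more. Where it says the series, first, only, none or still open, it means among the compounds named here.

Compound 1 `CCCCCCCCNC(=O)/C=C/c1c(/C=C/c2ccc(OC)cc2)cc(OC)cc1OC` is measured in a functional assay on MCF7 cells (Homo sapiens) for inhibition, read by MTT assay, with a stated time of 48 h (a higher number here means a weaker inhibitor, a lower number a stronger inhibitor), where compound 1 gives 4280 nM. Among the two numbers recorded so far this is the highest; the nearest is compound 2 `COc1ccc(/C=C/c2cc(OC)cc(OC)c2/C=C/C(=O)NC(C)C)cc1`, which in this assay gives 2560 nM. The step of a 1.7-fold lower number from compound 1 to compound 2 (0.22 log units; within the scatter) lies within the scatter, so the two compounds cannot be ordered against each other.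

Compound 3 `CCCCCCNC(=O)/C=C/c1c(/C=C/c2ccc(OC)cc2)cc(OC)cc1OC` differs from compound 1 in one place: hydrogen in place of ethyl on a saturated chain carbon, six bonds along the chain from an amide-type nitrogen. For the measured compounds named here, the only measured step that bears on this change is the one from compound 1 to compound 2, which also alters the group on the amide-type nitrogen, and that step stayed within the scatter. Nothing else in the measured pairs speaks to the length of the chain on that nitrogen.

For compound 3 the expected outcome in this assay is therefore a number close to that of compound 1, with no step beyond the scatter expected in either direction. The estimate for compound 3 is 3800 nM, with a range from 1900 nM to 7600 nM. The step this implies, a 1.1-fold lower number from compound 1 to compound 3 (0.05 log units; within the scatter), is expected to stay within the scatter.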

Compound 3, half-maximal inhibitory concentration: 5530 nM
Compound 3: middle estimate off by 1.5-fold (0.16 log units), on the low side, and the stated range covers the measured number.
By their numbers in this assay, from the lowest: compounds 2, 1 and 3 (each within the scatter of the next, the first and the last beyond it).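

Cutting octyl back to hexyl on the amide-type nitrogen, with hydrogen in place of ethyl six bonds along the chain, gives a 1.3-fold higher number from compound 1 to compound 3 (0.11 log units; within the scatter) in this assay, so this outer part of the chain can be shortened by two carbons without a readable change. Hexyl in place of isopropyl on the same nitrogen gives a 2.2-fold higher number from compound 2 to compound 3 (0.33 log units; beyond the scatter), the only step in the set that lies beyond the scatter, and a modest one, while compound 1 with its octyl chain stays within the scatter of both other compounds, so the three do not support a steady trend with chain length. No measurement shown here offers an explanation for these steps.

Going by these compounds, whether the modest step belongs to the branching of isopropyl or to the length of the chain remains open, and a straight propyl chain on that nitrogen would separate the two. Also open, on these data alone, is how a longer chain such as decyl, or a hexyl chain ending in an amine or a carboxylic acid, would read in this assay against compound 3.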